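A Dimethylphenyl Swap on a Shared Core

The source may report more compounds than this note shows. Statements on the series, on what has been measured and on what is new or still open speak of the compounds shown alone.

Of the compounds shown here, three on one core have been measured. Compound 1 `N#CC1=C(N)Oc2c(c3nc4ccccc4nc3c3ccccc23)C12C(=O)N(Cc1cnnn1-c1ccc([N+](=O)[O-])cc1)c1ccccc12` was tested in a functional assay on MCF7 cells (Homo sapiens) for antiproliferative activity, read by MTT assay, with a stated time of 48 h (a higher number here means a weaker inhibitor, a lower number a stronger inhibitor), and gave > 50000 nM, which is a limit of the assay. Compound 2 `Cc1cc(C)cc(-n2nncc2CN2C(=O)C3(C(C#N)=C(N)Oc4c3c3nc5ccccc5nc3c3ccccc43)c3ccccc32)c1` gave > 50000 nM, again a limit. Compound 3 `N#CC1=C(N)Oc2c(N)cc3nc4ccccc4nc3c2C12C(=O)N(Cc1cnnn1-c1ccc(F)cc1)c1ccccc12` gave > 50000 nM, also a limit. The step that the two limits leave unreadable from compound 1 to compound 2 cannot be read since both ends sit at the limit of > 50000 nM in this assay, at which 3 of the 3 values shown sit. Compound 3 therefore stands at the limit, as do both other compounds. Compound 4 `Cc1cc(C)cc(-n2nncc2CN2C(=O)C3(C(C#N)=C(N)Oc4c(N)cc5nc6ccccc6nc5c43)c3ccccc32)c1` differs from compound 3 in one place: 3,5-dimethylphenyl in place of 4-fluorophenyl on an aromatic nitrogen. For the measured compounds named here, no measured step gives a size for this change. The step that the limit leaves unreadable from compound 3 to compound 4 is expected to be none beyond the scatter. Compound 4 is therefore expected at 70000 nM, in the range 30000 nM to 200000 nM, most likely reported only as a limit.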

Compound 4, half-maximal inhibitory concentration: > 50000 nM
Compound 4: a limit, no number; the forecaster's own chance of this, stated with the estimate: 85%; the middle value is on the limit's open side.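

The step between compound 3 and compound 4 cannot be read, since both values are limits of the assay: the limit of > 50000 nM in this assay, at which 4 of the 4 values shown sit.

The compounds shown leave open what size, if any, the swap of 4-fluorophenyl for 3,5-dimethylphenyl has on antiproliferative activity.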